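Replacing the 4-methoxybenzyl group of compound 1

The compounds below may be only part of what the source reports. "The series", "measured", "known", "first", "only" and "open" are said of these compounds alone.

Among the compounds with values here, in a functional assay on EOL1 cells (Homo sapiens) for inhibition, read by fluorescence, with a stated time of 72 h (a higher number here means a weaker inhibitor of growth, a lower number a stronger inhibitor of growth), compound 1 `COc1ccc(Cn2cnc3c(Nc4cccc(Cl)c4)nc(N[C@H]4CC[C@H](N)CC4)nc32)cc1` gives 530 nM, the highest of the three numbers measured so far. Compound 2 `CC(C)CCn1cnc2c(Nc3ccccc3)nc(N[C@H]3CC[C@H](N)CC3)nc21` gives 10 nM and compound 3 `CCCCn1cnc2c(Nc3ccccc3)nc(N[C@H]3CC[C@H](N)CC3)nc21` gives 20 nM, both far lower. The change leading to compound 4 `CC(C)=CCC/C(C)=C/Cn1cnc2c(Nc3cccc(Cl)c3)nc(N[C@H]3CC[C@H](N)CC3)nc21` is 2,6-dimethylhepta-1,5-dien-1-yl in place of 4-methoxyphenyl on a saturated chain carbon bound to an aromatic nitrogen. Cut one bond further out, 4-methoxybenzyl gives way to 3,7-dimethylocta-2,6-dien-1-yl.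

Within the data shown here, the only measured step, a 2.0-fold higher number from compound 2 to compound 3 (0.30 log units; within the scatter), puts hydrogen in place of methyl on a chain and stays within the scatter. It bears only loosely on this change. Among the measured compounds shown here, compounds 2 and 3 carry open saturated chains but also differ from compound 4 elsewhere, and no measured pair shows the 4-methoxybenzyl group leaving. With compound 3 at 20 nM, a lower number than that of compound 1 is expected, though probably not one as low as this. The expected change is a 5.3-fold lower number from compound 1 to compound 4 (0.72 log units; beyond the scatter). Compound 4 is estimated at 100 nM, with an expected range from 25 nM to 400 nM.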

Compound 4, concentration for 50% growth inhibition: 590 nM
Beside the measured number, compound 4's estimate is 5.9-fold (0.77 log units) below it; measured number above the stated range.
By their numbers in this assay, from the lowest: compounds 2 and 3 (each within the scatter of the next); then compounds 1 and 4 (each within the scatter of the next).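

In this assay, within the data shown here, putting 2,6-dimethylhepta-1,5-dien-1-yl in place of 4-methoxyphenyl gives a 1.1-fold higher number from compound 1 to compound 4 (0.05 log units; within the scatter), the first measured pair in which the 4-methoxybenzyl group leaves. At this place, on a saturated chain carbon bound to an aromatic nitrogen, an open chain with two double bonds can therefore stand in for the aromatic ring with no readable change, and in this pair the open chain does not by itself lower the number. Nothing at hand explains why the two groups read alike.

As far as these compounds go, compounds 2 and 3 differ from compound 4 in more than the chain, so the part played by the chlorine stays open. Also open, from the compounds shown here alone, is how a short saturated chain such as ethyl, or a chain ending in a carboxylic acid, would read at this place on the core of compound 1.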